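This account rests on a few compounds, and the source may have more. Where it says the series, first, only, none or still open, it means among the compounds named here.

Two compounds share one core and have been run in a functional assay on Right cardiac atrium for agonist activity at histamine H2 receptor (Cavia porcellus), with a stated time of 30 min, in the presence of a further agent that is not named here; on this read-out lower numbers stand for smaller maximal responses and higher numbers for larger maximal responses. Compound 1 `Cc1nc(N)sc1CCCN/C(N)=N/C(=O)NC(C)c1ccc(Br)cc1` gives 0.87 in this assay. Compound 2 `Cc1nc(N)sc1CCCN/C(N)=N/C(=O)NC(C)c1ccc(Cl)cc1` gives 0.93 in this assay, and it stands alongside compound 1 on the numbers shown, because the step a number 0.060 higher from compound 1 to compound 2 (within the scatter) lies within the scatter, so the two cannot be separated. Compound 3 `Cc1nc(N)sc1CCCN/C(N)=N/C(=O)NC(C)c1ccc(OC(F)(F)F)cc1` has not yet been measured. It differs from compound 2 in one place: trifluoromethoxy in place of chloro on an aromatic carbon. For the measured compounds named here, the only measured step, chloro in place of bromo, bears on this change only loosely and was itself within the scatter. The numbers shown give no ground for a step beyond the scatter in this assay, so a step of about a number 0.030 lower from compound 2 to compound 3 (within the scatter) is expected, none beyond the scatter. Compound 3 is therefore estimated at 0.9 in this assay, with a range from 0.75 to 1.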

Compound 3, intrinsic activity: the largest response reached, as a fraction of the reference agonist's: 0.61
Compound 3: middle estimate off by 0.29, on the high side; the measured number lies below the stated range.
By their numbers in this assay, from the lowest: compound 3; then compounds 1 and 2 (each within the scatter of the next).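

The position on the aromatic ring is not indifferent to its substituent in this assay: although the chloro and bromo compounds could not be separated, trifluoromethoxy gives a number 0.32 lower from compound 2 to compound 3 (beyond the scatter) and, in place of bromo, a number 0.26 lower from compound 1 to compound 3 (beyond the scatter). The maximal response at this position can therefore be lowered by a change of a single group on the shared core, which the earlier halogen pair alone did not show. The entering group differs from the halogens in size and in carrying a hydrogen-bond acceptor, but no measurement shown accounts for the fall.

The compounds shown leave open whether the oxygen or the three fluorines matter more, and a methoxy or a trifluoromethyl group at this position would bear on that. Going by these compounds, how a fluoro group would stand against the chloro and bromo compounds also remains open.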